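Cyano for Methoxy on a Second Amide Core

This account rests on a few compounds, and the source may have more. Where it says the series, first, only, none or still open, it means among the compounds named here.

Of the compounds shown here, three have been measured in a functional assay on BMDM cells (Mus musculus, strain C57BL/6) for inhibition, with a stated time of 2 days; on this read-out lower numbers stand for stronger inhibition and higher numbers for weaker inhibition. Compound 1 `Cc1cc(NC(=O)Cn2cc(-c3ccc(C#N)cc3)nn2)no1` gives 9320 nM. Compound 2 `COc1ccc(-c2cn(CC(=O)Nc3cc(C)on3)nn2)cc1` reaches only the limit of > 30000 nM, which is a limit of this assay and not a number. Compound 3 `COc1ccc(-c2cn(CC(=O)Nc3nc4ccccc4s3)nn2)cc1` gives 1330 nM, the lowest of the two numbers. Compound 2 and compound 1 differ in one place (cyano in place of methoxy on an aromatic carbon), and the step of an at least 3.2-fold lower number from compound 2 to compound 1 (0.50 log units; beyond the scatter) can only be given as a floor because the limit of > 30000 nM in this assay, at which 1 of the 3 values shown sits, is where compound 2 sits. The difference between the core of compound 2 and that of compound 3 is not broken down here. Compound 4 `N#Cc1ccc(-c2cn(CC(=O)Nc3nc4ccccc4s3)nn2)cc1` carries the same change on the core of compound 3 (cyano in place of methoxy on an aromatic carbon). Compound 4 is therefore expected to show a step of a 3.3-fold lower number from compound 3 to compound 4 (0.52 log units; beyond the scatter) in this assay, resting on the step of an at least 3.2-fold lower number from compound 2 to compound 1 (0.50 log units; beyond the scatter) seen before. Compound 4 is estimated at 400 nM, between 150 nM and 1300 nM.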

Compound 4, half-maximal inhibitory concentration: > 30000 nM
Compound 4 was reported as a limit; the forecaster's own chance of this, stated with the estimate: 2%; middle value at least 75-fold (1.87 log units) away from the limit.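

On the core of compound 3, the change from 4-methoxyphenyl to 4-cyanophenyl gives an at least 22-fold higher number from compound 3 to compound 4 (1.35 log units; beyond the scatter) in this assay, so the step seen on the core of compound 2 does not carry over and its direction is reversed: the same change on two cores in this assay, an at least 3.2-fold lower number (0.50 log units; beyond the scatter) from compound 2 to compound 1 and an at least 22-fold higher number (1.35 log units; beyond the scatter) from compound 3 to compound 4, at least 72-fold (1.86 log units) apart, beyond the scatter of two such steps

The value of compound 4, > 30000 nM, is a limit of the assay and not a number.

The two pairs show that the outcome of this change differs between these two cores, but they do not show the true size of either step, as each pair rests on a limit: the limit of > 30000 nM in this assay, at which 2 of the 4 values shown sit.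

Left open is how an amine or a carboxylic acid in the same place would read on each core. As far as these compounds go, it is also open whether the reversal extends to any further core.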